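A few compounds are considered here, and "the series" means these few. Any claim that something is new, unique, unknown or untested is made for them only; others in the source may bear on it.

Working notes on the urea series. Two members have been measured in an assay on CHO cells for displacement of a labelled ligand from histamine receptor H3 (Macaca mulatta), read by scintillation counting, with a stated time of 1 h; on this read-out lower numbers stand for stronger inhibition and higher numbers for weaker inhibition. Compound 1 `Cc1c(Cl)cc(NC(=O)Nc2ccc(OCCCN3CCCCC3)cc2)cc1Cl` gives 18.2 nM in this assay. Compound 2 `CC1CCCN1C1CCN(c2ccc(NC(=O)Nc3cc(Cl)cc(Cl)c3)cc2)C1` gives 19.1 nM in this assay. The two numbers sit within the scatter of each other, so no order between compound 1 and compound 2 can be read from them; compound 2 stands at one end of this narrow pair only by its digit.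

The next member, compound 3 `Cc1cc(NC(=O)Nc2cc(Cl)cc(Cl)c2)ccc1N1CCC(N2CCCC2C)C1`, differs from compound 2 in a single place: methyl in place of hydrogen on an aromatic carbon, in words methyl in place of hydrogen on an aromatic carbon, ortho to a large group and meta to a large group. Within the data shown here, no measured pair in the set shows this change, so its size cannot be taken from the data. The small added group suggests a step that stays within the scatter, in either direction; the expected step from compound 2 to compound 3 is a 1.3-fold lower number from compound 2 to compound 3 (0.10 log units; within the scatter). For compound 3 the estimate in this assay is therefore 15 nM, with a range from 6 nM to 45 nM.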

Compound 3, inhibition constant: 43 nM
Beside the measured number, compound 3's estimate is 2.9-fold (0.46 log units) below it; low and high end bracket the measured number.
By their numbers in this assay, from the lowest: compounds 1 and 2 (each within the scatter of the next); then compound 3.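

Methyl in place of hydrogen on an aromatic carbon, ortho to a large group and meta to a large group, is the first single-place change in the series that can be read, and in this assay it gives a 2.3-fold higher number from compound 2 to compound 3 (0.35 log units; beyond the scatter). The position therefore responds to substitution: a methyl, with no ring, no hydrogen-bond donors or acceptors and no net charge, moves the number beyond the scatter, although the step is modest. Nothing measured on these compounds bears on the reason for this step.

Going by these compounds, whether fluorine, methoxy or a longer chain such as ethyl on the same aromatic carbon would give a step of similar direction and size remains open. One change at one position also cannot show whether the same methyl would have a similar effect on the core of compound 1.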